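Trifluoromethoxy added to compound 2: expected metabolic stability

The compounds below may be only part of what the source reports. "The series", "measured", "known", "first", "only" and "open" are said of these compounds alone.

Of the compounds shown here, two have been measured so far in an ADME assay on microsomes from liver (Rattus norvegicus) for metabolic stability, with a stated time of 10 min; a higher number here means that more of the compound is left, a lower number that less of the compound is left. Compound 1 (`FC(F)(F)c1ccccc1-c1ccc2[nH]c(C3=NCC4(CCCCC4)N3)nc2c1`) gives 91% and compound 2 (`Fc1ccccc1-c1ccc2[nH]c(C3=NOC4(CCCCC4)C3)nc2c1`) gives 55% as the lower of the two numbers. The gap between them lies beyond the usual scatter. The two compounds differ in more than one place, so no single structural step can be read from this pair.

Compound 3 (`Fc1cccc(OC(F)(F)F)c1-c1ccc2[nH]c(C3=NOC4(CCCCC4)C3)nc2c1`) is not yet measured. It differs from compound 2 by one change (trifluoromethoxy in place of hydrogen on an aromatic carbon): trifluoromethoxy in place of hydrogen on an aromatic carbon, ortho to a large group and meta to a fluoro group.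

Direct evidence for this change is lacking. Among the measured compounds shown here, the only guide is compound 1 (91%), which carries trifluoromethyl on a different core and offers weak support for an upward direction. The estimated change (a number 9 percentage points higher from compound 2 to compound 3 (within the scatter)) is a modest rise that may not clear the scatter. For compound 3 the expected value is 64% in this assay with an estimated range of (43% to 85%).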

Compound 3, percent of the compound remaining: 44%
Beside the measured number, compound 3's estimate is 20 percentage points above it; measured number inside the range.
By their numbers in this assay, from the lowest: compound 3; then compound 2; then compound 1.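

In this assay, among the compounds shown here, trifluoromethoxy on this aromatic carbon, ortho to a large group and meta to a fluoro group, gives a number 11 percentage points lower from compound 2 to compound 3 (beyond the scatter) and so provides the first step that can be read at a single position. The step is modest but beyond the scatter, so on this core the position is not indifferent to substitution, and with trifluoromethoxy there less of the compound is left. No available data bear on the reason for this drop.

The compounds shown hold only this one added group at the position, so it remains open whether the drop belongs to trifluoromethoxy itself or would also appear with a methyl, a chloro or a nitrile on the same carbon. As far as these compounds go, it also remains open whether the same change would lower the number on the core of compound 1, which gives 91% and differs from compound 2 and compound 3 in more than one place.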